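A few compounds are considered here, and "the series" means these few. Any claim that something is new, unique, unknown or untested is made for them only; others in the source may bear on it.

Measured compounds in an assay on isolated protein for inhibition of tyrosine-protein phosphatase non-receptor type 13 (Homo sapiens), read by spectrophotometry; a higher number here means a weaker inhibitor, a lower number a stronger inhibitor:
compound 1 `O=C(COc1ccc2cc(C(O)(C(F)(F)F)C(F)(F)F)c(O)cc2c1)Nc1ccccc1`: > 20000 nM
compound 2 `O=C(COc1ccc2cc(C(O)(C(F)(F)F)C(F)(F)F)c(O)cc2c1)Nc1cccc2ccccc12`: > 20000 nM
compound 3 `O=C(COc1ccc2cc(C(O)(C(F)(F)F)C(F)(F)F)c(O)cc2c1)NCc1ccc(F)cc1`: > 20000 nM

Each of these values is a limit of this assay and not a number; (the limit of > 20000 nM in this assay, at which 3 of the 3 values shown sit). Compound 3 therefore stands at that limit, and nothing measured places it relative to the other two. The steps a step that the two limits leave unreadable from compound 1 to compound 3 and a step that the two limits leave unreadable from compound 2 to compound 3 are unreadable, as is a step that the two limits leave unreadable from compound 1 to compound 2. Compound 4 `O=C(COc1ccc2cc(C(O)(C(F)(F)F)C(F)(F)F)c(O)cc2c1)Nc1ccc(-c2ccccc2)cc1` differs from compound 3 by 4-phenylphenyl in place of 4-fluorobenzyl on an amide-type nitrogen. Among the compounds with values here, no measured step gives a readable size for a change on the amide-type nitrogen, so no direction can be drawn from them. Compound 4 is expected to sit at or beyond the same limit, the step that the limit leaves unreadable from compound 3 to compound 4 being an estimate only. The estimate for compound 4 in this assay is 30000 nM, between 8000 nM and 100000 nM.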

Compound 4, half-maximal inhibitory concentration: 2800 nM
Estimate against measurement, compound 4: 11-fold (1.03 log units) above; measured number below the stated range.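

In this assay the amide-type nitrogen now gives readable steps: 4-phenylphenyl brings an at least 7.1-fold lower number from compound 3 to compound 4 (0.85 log units; beyond the scatter) in place of 4-fluorobenzyl and an at least 7.1-fold lower number from compound 2 to compound 4 (0.85 log units; beyond the scatter) in place of naphthalen-1-yl. On the phenyl group itself, phenyl in place of hydrogen on an aromatic carbon brings an at least 7.1-fold lower number from compound 1 to compound 4 (0.85 log units; beyond the scatter) and is the smallest change that does so. Only compound 4 leaves the limit, which holds the other three compounds: the limit of > 20000 nM in this assay, at which 3 of the 4 values shown sit.

The steps among compound 1, compound 2 and compound 3 cannot be read. Going by these compounds, whether a carboxylic acid or an amine on the 4-phenylphenyl group would hold this gain stays open.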